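Replacing the methoxyphenyl of compound 2 with a difluorophenyl

The source may hold more compounds than are shown below. What is called first, only, known or untested is meant among the compounds shown, and "the series" means these compounds.

Measured compounds:
compound 1 `COc1ccc(C(=O)/C=C/c2cc(-c3cc(OC)c(OC)c(OC)c3)n[nH]2)cc1OC` gives 3510 nM
compound 2 `COc1ccc(C(=O)/C=C/c2cc(-c3cc(OC)c(OC)c(OC)c3)n[nH]2)cc1` gives 19600 nM

In a functional assay on SK-MEL-2 cells (Homo sapiens) for inhibition, read by sulforhodamine B assay, with a stated time of 48 h (on this read-out lower numbers stand for stronger inhibition of growth and higher numbers for weaker inhibition of growth), compound 2 gives 19600 nM, the highest of the two numbers measured. Its nearest neighbour is compound 1, and the step of a 5.6-fold higher number from compound 1 to compound 2 (0.75 log units; beyond the scatter) came with hydrogen in place of methoxy on an aromatic carbon. Compound 3 `COc1cc(-c2cc(/C=C/C(=O)c3ccc(F)c(F)c3)[nH]n2)cc(OC)c1OC` has not been measured. It differs from compound 2 by 3,4-difluorophenyl in place of 4-methoxyphenyl on a carbonyl carbon. Within the data shown here, no measured step makes this kind of change; the only recorded step, a 5.6-fold higher number from compound 1 to compound 2 (0.75 log units; beyond the scatter), alters a substituent on the same ring and shows that such alterations can move the number beyond the scatter, but which way a difluorophenyl would move it cannot be read from these two compounds. The step from compound 2 to compound 3 is therefore expected to be modest, a 1.3-fold lower number from compound 2 to compound 3 (0.12 log units; within the scatter), with a wide margin of doubt. Compound 3 is estimated at 15000 nM, in a range from 4000 nM to 50000 nM.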

Compound 3, concentration for total growth inhibition: 5890 nM
The estimate for compound 3 lay 2.5-fold (0.41 log units) above the measured number, and the stated range covers the measured number.
By their numbers in this assay, from the lowest: compounds 1 and 3 (each within the scatter of the next); then compound 2.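

In this assay, 3,4-difluorophenyl in place of 4-methoxyphenyl on the carbonyl carbon gave a 3.3-fold lower number from compound 2 to compound 3 (0.52 log units; beyond the scatter) and so improved on compound 2, which shows that this position tolerates an aryl group carrying no methoxy at all. Set against the 3,4-dimethoxyphenyl group, the same change gave a 1.7-fold higher number from compound 1 to compound 3 (0.22 log units; within the scatter) and so left no distinction between these two groups, whereas the earlier pair showed only that removing one methoxy raised the number. Nothing available accounts for either step.

Going by these compounds, whether 4-fluorophenyl alone would match these two compounds remains open, as does the outcome with an amine such as 4-aminophenyl or with 3,4-dichlorophenyl at this carbonyl carbon. The rest of the core is the same in all three compounds, so what changes there would do is also unknown.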